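This account rests on a few compounds, and the source may have more. Where it says the series, first, only, none or still open, it means among the compounds named here.

Three compounds have been measured in a functional assay on DU-145 cells (Homo sapiens) for inhibition, read by sulforhodamine B assay, with a stated time of 48 h; a lower number here means a stronger inhibitor of growth, a higher number a weaker inhibitor of growth:

Compound 1 `Nc1cc(N)c2nc(-c3ccccc3)c(NCc3ccc(F)cc3)nc2c1` gives 1510 nM in this assay.
Compound 2 `COc1ccc(CNc2nc3cc(N)cc(N)c3nc2-c2ccccc2)cc1` gives 21900 nM in this assay.
Compound 3 `COc1ccc(Sc2nc3cc(N)cc(N)c3nc2-c2ccccc2)cc1` gives 16200 nM in this assay.

Compound 3 stands second highest of these three numbers. Its value and that of compound 2 lie within the scatter of each other, while compound 1 sits far lower, as the step of an 11-fold higher number from compound 1 to compound 3 (1.03 log units; beyond the scatter) shows. Compound 4 `Nc1cc(N)c2nc(-c3ccccc3)c(Sc3ccc(F)cc3)nc2c1` differs from compound 3 by fluoro in place of methoxy on an aromatic carbon. Among the measured steps, only a 15-fold higher number from compound 1 to compound 2 (1.16 log units; beyond the scatter) bears on this change: there, in the pair built on a (4-fluorobenzyl)amino group, methoxy in place of fluoro raised the number strongly. Read in reverse, fluoro in place of methoxy on the (4-methoxyphenyl)sulfanyl ring is therefore expected to lower the number by a comparable amount, although the supporting evidence is a single step in a differently linked pair, so the expectation carries wide uncertainty. The estimated step from compound 3 is a 6.5-fold lower number from compound 3 to compound 4 (0.81 log units; beyond the scatter). Compound 4 is expected to give about 2500 nM, with a range from 800 nM to 8000 nM.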

Compound 4, concentration for 50% growth inhibition: < 100000 nM
Compound 4 gave a limit, no number; the forecaster's own chance of this, stated with the estimate: 3%; the middle value does not contradict the limit.
By their numbers in this assay, from the lowest: compound 1; then compounds 3 and 2 (each within the scatter of the next).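

In this assay compound 4 gives < 100000 nM, which is a limit and not a number. The steps to compound 4 from compound 1 and from compound 3 therefore cannot be read. The compounds shown leave open whether fluoro in place of methoxy on the sulfanyl-linked ring shifts the number as it does between compound 2 and compound 1.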